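The compounds below may be only part of what the source reports. "The series", "measured", "known", "first", "only" and "open" are said of these compounds alone.

Working notes on the series. Of the compounds shown here, three sharing one core have been measured in a functional assay on OVCAR cells (Homo sapiens) for inhibition, read by MTT assay, with a stated time of 48 h; on this read-out lower numbers stand for stronger inhibition of growth and higher numbers for weaker inhibition of growth. Compound 1 `COc1ccc(-c2cc(-c3ccccc3)n[nH]2)cc1` gives 9900 nM; compound 2 `Oc1ccc(-c2cc(-c3ccc(C(F)(F)F)cc3)n[nH]2)cc1` gives 9200 nM; compound 3 `COc1ccccc1-c1cc(-c2ccccc2-c2ccccc2)n[nH]1` gives 14200 nM. On these numbers compound 3 stands highest of the three, yet its gaps to compound 1 and to compound 2 both lie within the usual scatter, so no order among them can be read.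

Compound 4 `Nc1ccc(-c2cc(-c3ccccc3-c3ccccc3)n[nH]2)cc1` is not yet measured. It differs from compound 3 in one place: 4-aminophenyl in place of 2-methoxyphenyl on an aromatic carbon. Among the compounds with values here, no single-change step between measured compounds exists to calibrate this exchange. Within the data shown here, the three values so far sit close together despite varied substitution, so a step from compound 3 to compound 4 of a 1.4-fold lower number from compound 3 to compound 4 (0.15 log units; within the scatter) is expected, that is none beyond the scatter. Compound 4 is estimated at 10000 nM in this assay, with a range of 4000 nM to 25000 nM.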

Compound 4, concentration for 50% growth inhibition: 17900 nM
For compound 4 the middle estimate is 1.8-fold (0.25 log units) below the measured one; measured number inside the range.
By their numbers in this assay, from the lowest: compounds 2, 1, 3 and 4 (each within the scatter of the next).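

Within the data shown here, putting 4-aminophenyl in place of 2-methoxyphenyl on this aromatic carbon gives a 1.3-fold higher number from compound 3 to compound 4 (0.10 log units; within the scatter), the only single-place step so far. The exchange adds a hydrogen-bond donor and removes a ring substituent from one placement to another, yet the number does not move beyond the scatter. No measurement that bears on a cause accompanies this step.

From the compounds shown here alone, whether any group at this carbon can move the number beyond the scatter stays open. A carboxylic acid on the phenyl ring, or a longer chain in place of the amine, would test this.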